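A few compounds are considered here, and "the series" means these few. Any claim that something is new, unique, unknown or untested is made for them only; others in the source may bear on it.

Compound 1 `O=C(O)COc1ccc(NCc2ccc(Cl)c(-c3ccccc3)c2)cc1F`: 51.7 nM
Compound 2 `O=C(O)COc1ccc(NCc2cccc(-c3ccccc3Cl)c2)cc1F`: 19.3 nM

Of the compounds shown here, two have been measured in a functional assay on CHO cells for agonist activity at Free fatty acid receptor 1 (Homo sapiens), read by FLIPR and calcium flux; a lower number here means that less compound is needed, a higher number that more compound is needed for the effect. Compound 1 gives 51.7 nM in this assay, and compound 2 gives 19.3 nM; compound 2 thus holds the lower of the two numbers, and the gap between them lies beyond the usual scatter. Compound 3 `Cc1ccc(-c2cccc(CNc3ccc(OCC(=O)O)c(F)c3)c2)c(Cl)c1` has not been measured. It differs from compound 2 in one place: methyl in place of hydrogen on an aromatic carbon. Among the measured compounds shown here, no measured pair shows what such a change does here, so the expectation rests on the small size of the group that enters. A methyl in place of hydrogen on an aromatic carbon is expected to leave the number near that of compound 2, with any shift no larger than the scatter or only slightly beyond it, and most likely toward a somewhat lower number. On that basis compound 3 is estimated at 15 nM, within a range of 6 nM to 40 nM, which means an expected step of a 1.3-fold lower number from compound 2 to compound 3 (0.11 log units; within the scatter).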

Compound 3, half-maximal effective concentration: 22.5 nM
Beside the measured number, compound 3's estimate is 1.5-fold (0.18 log units) below it; the range from low to high includes it.
By their numbers in this assay, from the lowest: compounds 2 and 3 (each within the scatter of the next); then compound 1.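

The change from 2-chlorophenyl to 2-chloro-4-methylphenyl gives the first single-place step among these compounds, and in this assay it reads a 1.2-fold higher number from compound 2 to compound 3 (0.07 log units; within the scatter). A methyl on this aromatic carbon, meta to the chloro group and para to a large group, therefore leaves the number within the scatter of that of compound 2, so neither compound can be ranked above the other. No measurement shown explains this result.

On these data alone, whether this carbon accepts a larger or different group, such as an ethyl, a methoxy, an amine or a carboxylic acid, remains open. The compounds shown also leave open whether a methyl at this place would give the same result without the chloro group.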